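A chloro in place of methyl, at the limit

This account rests on a few compounds, and the source may have more. Where it says the series, first, only, none or still open, it means among the compounds named here.

Compound 1 `Cc1ccc([C@@H](C)Oc2cc3onc(CCC(=O)O)c3cc2Cl)nc1` is the starting point in a physicochemical assay for pharmacokinetics, at pH 6; a higher number here means that the compound lasts longer, a lower number that the compound disappears faster. There compound 1 gives > 1000 h, which is a limit of the assay and not a number. Among the compounds with values here, compound 2 `O=C(O)CCn1c(=O)oc2cc(OCC3CC3)c(Cl)cc21`, the only other compound measured, gives > 1000 h, and this too is a limit. Within the data shown here, the measurements so far therefore sit together at the limit of > 1000 h in this assay, at which 2 of the 2 values shown sit, and no measured step between compounds is available as a guide.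

Compound 3 `C[C@@H](Oc1cc2onc(CCC(=O)O)c2cc1Cl)c1ccc(Cl)cn1` departs from compound 1 in a single place: chloro in place of methyl on an aromatic carbon. In words, this is chloro in place of methyl on an aromatic carbon, turning 5-methylpyridin-2-yl into 5-chloropyridin-2-yl, while the rest of the structure stays the same.

No change beyond the usual scatter is expected in this assay, an expectation that rests on compound 1 with its limit of > 1000 h. The expected step of a number no higher from compound 1 to compound 3 (the limit leaves the size open) is accordingly small. For compound 3 the estimated value is 1000 h, with an expected range of 500 h to 2000 h, and the reading may well prove to be a limit again.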

Compound 3, half-life: > 1000 h
Compound 3: no number, only a limit; the forecaster's own chance of this, stated with the estimate: 90%; the middle value sits exactly at the limit.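

In this assay compound 3 gives > 1000 h, which is a limit of the assay and not a number. Compound 1 also stands at a limit, and no step between compound 1 and compound 3 can be read: the limit of > 1000 h in this assay, at which 3 of the 3 values shown sit.

The compounds shown leave open how long any of them lasts beyond that limit, and whether chloro in place of methyl on an aromatic carbon changes the half-life at all.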